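The source may report more compounds than this note shows. Statements on the series, on what has been measured and on what is new or still open speak of the compounds shown alone.

Compound 1 `CNCC(=O)N1N=C(c2cc3ccccc3oc2=O)CC1c1ccccc1` and compound 2 `CCCNCC(=O)N1N=C(c2cc3ccccc3oc2=O)CC1c1ccccc1` share one core and differ only in the group on the amine nitrogen. In a functional assay on MGC-803 cells (Homo sapiens) for cytotoxicity, read by MTT assay, with a stated time of 48 h (on this read-out lower numbers stand for stronger inhibition and higher numbers for weaker inhibition), compound 1 gives 12800 nM, and compound 2 gives 4880 nM; the step of a 2.6-fold lower number from compound 1 to compound 2 (0.42 log units; beyond the scatter) is the only measured one. Compound 3 `CC1CC(C)CN(CC(=O)N2N=C(c3cc4ccccc4oc3=O)CC2c2ccccc2)C1` carries a ring on that chain carbon instead, and in this assay compound 3 gives "not active" (no number reported), so no number places it among the others. Compound 4 `NC(=O)C1CCN(CC(=O)N2N=C(c3cc4ccccc4oc3=O)CC2c2ccccc2)CC1` differs from compound 3 by 4-carbamoylpiperidin-1-yl in place of 3,5-dimethylpiperidin-1-yl on a saturated chain carbon bound to a carbonyl carbon. Among the measured compounds shown here, no measured step bears on this change, and the measured step concerns a different position, so no direction beyond the scatter can be foreseen. On that footing compound 4 is expected near 20000 nM, within 5000 nM to 80000 nM.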

Compound 4, half-maximal inhibitory concentration: 21500 nM
For compound 4 the middle estimate is 1.1-fold (0.03 log units) below the measured one; the measured number falls inside the stated range.
By their numbers in this assay, from the lowest: compound 2; then compounds 1 and 4 (each within the scatter of the next).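

In this assay a ring on the saturated chain carbon bound to a carbonyl carbon can now be compared by number: a 4.4-fold higher number from compound 2 to compound 4 (0.64 log units; beyond the scatter) and so lies beyond the scatter, whereas a 1.7-fold higher number from compound 1 to compound 4 (0.23 log units; within the scatter) and so lies within it. The 4-carbamoylpiperidin-1-yl and methylamino groups therefore cannot be told apart here, while the propylamino group stays ahead of both. The step from compound 3 cannot be read, and no evidence explains these differences. Still open, going by these compounds, is whether a butylamino chain would lower the number further, and whether a carboxylic acid in place of the carbamoyl group would change it.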